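From Methyl to Dichloro on the Aryl Urea Terminus

The source may report more compounds than this note shows. Statements on the series, on what has been measured and on what is new or still open speak of the compounds shown alone.

Three compounds sharing one core have been examined in a functional assay on T-24 cells (Homo sapiens) for antiproliferative activity, read by MTT assay, with a stated time of 48 h; on this read-out higher numbers stand for weaker inhibition and lower numbers for stronger inhibition. Compound 1 `Cc1cccc(NC(=O)Nc2cccc(CNc3nccnc3Cl)c2)c1` gives 9570 nM. Compound 2 `O=C(Nc1cccc(CNc2nccnc2Cl)c1)Nc1cccc(C(F)(F)F)c1` gives 5080 nM, and compound 3 `CS(=O)(=O)c1ccc(NC(=O)Nc2cccc(CNc3nccnc3Cl)c2)cc1` gives 29300 nM. Among these three numbers compound 1 stands second highest: its gap to compound 2 is within the scatter, while compound 3 gives a clearly higher number, beyond the scatter.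

Compound 4 `O=C(Nc1cccc(CNc2nccnc2Cl)c1)Nc1ccc(Cl)c(Cl)c1` is not yet measured. It differs from compound 1 in one place: 3,4-dichlorophenyl in place of 3-methylphenyl on an amide-type nitrogen. Among the measured compounds shown here, the only measured step that bears on this change is a 1.9-fold lower number from compound 1 to compound 2 (0.28 log units; within the scatter), which also reworks the 3-methylphenyl of compound 1 and stays within the scatter. On that basis a small downward movement, of about the same size or slightly larger, is the expectation for the step of a 2.4-fold lower number from compound 1 to compound 4 (0.38 log units; beyond the scatter). Compound 4 is accordingly estimated at 4000 nM, with a range from 1500 nM to 12000 nM, and the outcome will decide whether the change matters at all.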

Compound 4, half-maximal inhibitory concentration: 5210 nM
Beside the measured number, compound 4's estimate is 1.3-fold (0.11 log units) below it, within the range that was stated.
By their numbers in this assay, from the lowest: compounds 2, 4 and 1 (each within the scatter of the next); then compound 3.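

In this assay, putting 3,4-dichlorophenyl in place of 3-methylphenyl on the amide-type nitrogen gives a 1.8-fold lower number from compound 1 to compound 4 (0.26 log units; within the scatter), so a second replacement at this position leaves the number within the scatter. Read with a 1.9-fold lower number from compound 1 to compound 2 (0.28 log units; within the scatter), this makes two changes to the 3-methylphenyl of compound 1 that do not move the number beyond the scatter, while compound 3, at 29300 nM, remains the only one of the four set apart. No measurement at hand offers an explanation for these numbers.

Going by these compounds, it remains open whether an aryl group carrying an amine or a carboxylic acid at this position would stay with compound 1, compound 2 and compound 4 or rise towards compound 3. All four compounds keep the same core, and what a methoxy group in place of its chlorine would do is also unknown.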